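This account rests on a few compounds, and the source may have more. Where it says the series, first, only, none or still open, it means among the compounds named here.

Measured in a functional assay on cells (Homo sapiens) for inhibition, read by MTT assay, with a stated time of 72 h (a lower number here means a stronger inhibitor, a higher number a weaker inhibitor), all three values being limits:
- Compound 1 `CCOC(=O)Cn1ncc2c(Nc3ccc(NS(=O)(=O)c4ccc([N+](=O)[O-])cc4)cc3)ncnc21`: > 64 ug/mL
- Compound 2 `CCOC(=O)Cn1ncc2c(Nc3ccc(NC(=O)c4ccccc4)cc3)ncnc21`: > 100 ug/mL
- Compound 3 `CCOC(=O)Cn1ncc2c(Nc3ccc(NC(C)=O)cc3)ncnc21`: > 64 ug/mL

Compound 3 stands only at a limit, > 64 ug/mL, shared as in the limit of > 64 ug/mL in this assay, at which 2 of the 3 values shown sit. Compound 4 `CCOC(=O)Cn1ncc2c(Nc3ccc(NS(=O)(=O)c4ccc(Br)cc4)cc3)ncnc21` is next, with (4-bromophenyl)sulfonyl in place of acetyl on a nitrogen on an aromatic ring. Among the measured compounds shown here, the one measured step, a step that the two limits leave unreadable from compound 2 to compound 3, gives no size to carry over. The other limit in the set is the limit of > 100 ug/mL in this assay, at which 1 of the 3 values shown sits. The expectation therefore rests on compound 1, which gives only the limit > 64 ug/mL. In this assay no readable step is expected, and no direction can be assigned to the estimated step that the limit leaves unreadable from compound 3 to compound 4. A further limit is the likeliest report. For compound 4 the estimated value is 70 ug/mL, with an expected range of 30 ug/mL to 120 ug/mL.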

Compound 4, half-maximal inhibitory concentration: > 64 ug/mL
Compound 4 gave a limit, no number (the forecaster's own chance of this, stated with the estimate: 65%); the middle value lies beyond the limit too.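

In this assay compound 4 gives > 64 ug/mL, a limit. The steps from compound 1, compound 2 and compound 3 to compound 4 cannot be read: each pair is a pair of limits. The compounds shown leave open how strongly any of the four inhibits, and whether the group on the nitrogen matters at all.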